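The source may report more compounds than this note shows. Statements on the series, on what has been measured and on what is new or still open speak of the compounds shown alone.

Three members of the series have a value in a functional assay on A2780 cells (Homo sapiens) for cytotoxicity, read by MTT assay, with a stated time of 72 h; a higher number here means a weaker inhibitor, a lower number a stronger inhibitor. Compound 1 `CN1[C@@H]2c3[nH]c4ccccc4c3C[C@H]1[C@H](C#N)N1[C@@H](CNC(=O)c3ccc(Cl)cc3)c3[nH]c4ccccc4c3C[C@@H]21` gives 230 nM, compound 2 `CN1[C@@H]2c3[nH]c4ccccc4c3C[C@H]1[C@H](C#N)N1[C@@H](CNC(=O)c3ccc(F)cc3)c3[nH]c4ccccc4c3C[C@@H]21` gives 250 nM, and compound 3 `CCc1ccc(C(=O)NC[C@H]2c3[nH]c4ccccc4c3C[C@H]3[C@H]4c5[nH]c6ccccc6c5C[C@@H]([C@H](C#N)N23)N4C)cc1` gives 670 nM. Compound 3 holds the highest number of the three: the step of a 2.9-fold higher number from compound 1 to compound 3 (0.46 log units; beyond the scatter) and the step of a 2.7-fold higher number from compound 2 to compound 3 (0.43 log units; beyond the scatter) both lie beyond the scatter, whereas the step of a 1.1-fold higher number from compound 1 to compound 2 (0.04 log units; within the scatter) does not. Compound 4 `CN1[C@@H]2c3[nH]c4ccccc4c3C[C@H]1[C@H](C#N)N1[C@@H](CNC(=O)c3ccc4ccccc4n3)c3[nH]c4ccccc4c3C[C@@H]21` has not been measured in this assay. It differs from compound 3 by quinolin-2-yl in place of 4-ethylphenyl on a carbonyl carbon. For the measured compounds named here, no measured step replaces the aromatic ring itself; the only steps touching this part of the molecule are those from compound 1 and compound 2 to compound 3, which exchange one substituent on the ring for another and shift the number modestly. The present change is of a different kind, so the direction is uncertain, and the expected step is a 1.5-fold lower number from compound 3 to compound 4 (0.17 log units; within the scatter), without grounds for more than a modest shift either way. Compound 4 is therefore estimated at 450 nM, within a range of 150 nM to 1300 nM.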

Compound 4, half-maximal inhibitory concentration: 60 nM
Compound 4: middle estimate off by 7.5-fold (0.88 log units), on the high side, and the stated range ends above it.
By their numbers in this assay, from the lowest: compound 4; then compounds 1 and 2 (each within the scatter of the next); then compound 3.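

In this assay, the position on the carbonyl carbon responds more strongly to exchanging the whole aromatic group than the substituent exchanges on the phenyl ring suggested: quinolin-2-yl gives an 11-fold lower number from compound 3 to compound 4 (1.05 log units; beyond the scatter) and also a 4.2-fold lower number from compound 2 to compound 4 (0.62 log units; beyond the scatter) and a 3.8-fold lower number from compound 1 to compound 4 (0.58 log units; beyond the scatter) in the same direction. All three steps lie beyond the scatter, so compound 4 is the strongest of the four, and the phenyl ring is not required at this position for activity in this assay. Nothing available here accounts for this gain.

The compounds shown leave open whether the gain follows the ring nitrogen or the second ring of quinolin-2-yl, a question that pyridin-2-yl and naphthalen-2-yl groups on the same carbonyl carbon would separate. Also open, on these data alone, is whether an amine or a carboxylic acid on the quinolin-2-yl group would keep the gain.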